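Trifluoromethyl for a pentafluorosulfanyl group on two cores

A few compounds are considered here, and "the series" means these few. Any claim that something is new, unique, unknown or untested is made for them only; others in the source may bear on it.

Measured so far:
Compound 1, `CC(O)(CSc1ccc(S(F)(F)(F)(F)F)cc1)C(=O)Nc1cccc(S(F)(F)(F)(F)F)c1`, gives 12700 nM.
Compound 2, `CC(O)(CSc1ccc(C(F)(F)F)cc1)C(=O)Nc1cccc(S(F)(F)(F)(F)F)c1`, gives 17500 nM.
Compound 3, `CC(O)(COc1cccc(S(F)(F)(F)(F)F)c1)C(=O)Nc1ccc(S(F)(F)(F)(F)F)cc1`, gives 12000 nM.

All three were tested in a functional assay on LNCaP cells (Homo sapiens) for antiproliferative activity, read by propidium iodide staining, with a stated time of 96 h; a higher number here means a weaker inhibitor, a lower number a stronger inhibitor. Compound 1 gives 12700 nM and compound 2 gives 17500 nM; the step between them, a 1.4-fold higher number from compound 1 to compound 2 (0.14 log units; within the scatter), is a group of 4 heavy atoms (1 carbon, 3 fluorine; no ring) in place of a group of 6 heavy atoms (5 fluorine, 1 sulfur; no ring), on an aromatic carbon. Compound 3 gives 12000 nM; it and compound 1 lie within the scatter of each other, as do compound 3 and compound 2. How the core of compound 3 differs from the core of compound 1 is not broken down here.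

Compound 4, `CC(O)(COc1cccc(C(F)(F)F)c1)C(=O)Nc1ccc(S(F)(F)(F)(F)F)cc1`, has not yet been measured in this assay. It is reached from compound 3 by the same kind of change, (a group of 4 heavy atoms (1 carbon, 3 fluorine; no ring) in place of a group of 6 heavy atoms (5 fluorine, 1 sulfur; no ring), on an aromatic carbon). The place is not the same word for word: in compound 1 the group sits para to a large group, in compound 3 meta to a large group. Because the earlier step of a 1.4-fold higher number from compound 1 to compound 2 (0.14 log units; within the scatter) stayed within the scatter, the step from compound 3 to compound 4 is expected to be similar in size, a 1.3-fold higher number from compound 3 to compound 4 (0.12 log units; within the scatter), resting on that single precedent. For compound 4 the estimate in this assay is 16000 nM, expected between 8000 nM and 32000 nM.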

Compound 4, half-maximal inhibitory concentration: 24700 nM
Beside the measured number, compound 4's estimate is 1.5-fold (0.19 log units) below it; measured number inside the range.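

In this assay, putting trifluoromethyl in place of the pentafluorosulfanyl group on the core of compound 3, meta to a large group, gives a 2.1-fold higher number from compound 3 to compound 4 (0.31 log units; beyond the scatter), a modest step. Both steps on the two cores point towards a higher number, although only the newer one lies beyond the scatter, and their sizes cannot be told apart: the same change on two cores in this assay, a 1.4-fold higher number (0.14 log units; within the scatter) from compound 1 to compound 2 and a 2.1-fold higher number (0.31 log units; beyond the scatter) from compound 3 to compound 4, 1.5-fold (0.17 log units) apart, within the scatter of two such steps This shows that the change can be carried from one core to the other without a detectable difference in its size, but it rests on two pairs only, gives no firm size for the change, and cannot separate the effect of the core from that of the place of the group, which also differs between the pairs.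

The compounds shown leave open how the step would read on the second pentafluorosulfanyl group that compound 3 and compound 4 carry, on the ring attached to the amide nitrogen. They also leave open where a nitrile or a chlorine atom on the same aromatic carbon would fall, and whether an amine in place of the hydroxyl group would alter the size of the step.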